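The compounds below may be only part of what the source reports. "The series", "measured", "known", "first", "only" and "open" are said of these compounds alone.

Among the measured compounds shown here, compound 2 `COc1ccc(-c2c(C)nc3c(NCc4cccnc4)cc(C)cn23)cc1OC` stands highest of the two numbers so far in a physicochemical assay for lipophilicity, at pH 7.4 (on this read-out higher numbers stand for higher lipophilicity and lower numbers for lower lipophilicity), where compound 2 gives 4.9. Its nearest neighbour is compound 1 `COc1ccc(-c2c(C)nc3c(NCc4ccc(C(N)=O)cc4)cc(C)cn23)cc1OC`, which in this assay gives 4.3; the step of a number 0.60 log units higher from compound 1 to compound 2 (beyond the scatter) is the only measured one, and it shows that swapping the group on the saturated chain carbon bound to a nitrogen on the aromatic ring can move the read-out by a modest amount. Compound 3 `COc1ccc(-c2c(C)nc3c(NCC4CCOCC4)cc(C)cn23)cc1OC` differs from compound 2 in that same place: oxan-4-yl in place of pyridin-3-yl on a saturated chain carbon bound to a nitrogen on an aromatic ring. For the measured compounds named here, no measured step covers this particular exchange, so the expectation rests on the one step at that position and on the fact that an aromatic ring with one hetero atom gives way to a non-aromatic ring with one hetero atom. For compound 3 a step of a number 0.20 log units lower from compound 2 to compound 3 (within the scatter) is expected, that is little change beyond the scatter and if anything a slightly lower number. Compound 3 is therefore estimated at 4.7 in this assay, within a range from 4.1 to 5.3.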

Compound 3, distribution coefficient: 6
The estimate for compound 3 lay 1.30 log units below the measured number; measured number above the stated range.
By their numbers in this assay, from the lowest: compound 1; then compound 2; then compound 3.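

In this assay, the exchange of pyridin-3-yl for oxan-4-yl gives a number 1.10 log units higher from compound 2 to compound 3 (beyond the scatter) even though both groups have the same counts of heavy atoms, hydrogen-bond donors and hydrogen-bond acceptors, so matching counts do not make these two rings equivalent at this place. Taken with a number 1.70 log units higher from compound 1 to compound 3 (beyond the scatter) across the same place, on a saturated chain carbon bound to a nitrogen on an aromatic ring, this shows a wider span at this position than the one earlier step revealed. No evidence here bears on what lies behind these steps. The compounds shown leave open whether the higher number goes with the non-aromatic ring as such or with oxan-4-yl in particular. A cyclohexyl ring, a piperidin-4-yl amine or a longer chain at this place would each bear on that question.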